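Crown ether esters: alkenyl versus aromatic acyl chains

A few compounds are considered here, and "the series" means these few. Any claim that something is new, unique, unknown or untested is made for them only; others in the source may bear on it.

Compound 1 `O=C(CCCCCc1ccccc1)OCC1COCCOCCOCCOCCOCCO1` carries 4-phenylbutyl on the saturated chain carbon bound to the carbonyl carbon; in a functional assay on HBL-100 cells (Homo sapiens) for inhibition, read by sulforhodamine B assay, with a stated time of 48 h (a higher number here means a weaker inhibitor of growth, a lower number a stronger inhibitor of growth), compound 1 gives 64000 nM. Compound 2 `CC/C=C/CC(=O)OCC1COCCOCCOCCOCCOCCO1` has but-1-en-1-yl in that place. In this assay compound 2 reaches only a limit of the assay, > 100000 nM, so no number of its own is known. The step of an at least 1.5-fold higher number from compound 1 to compound 2 (0.19 log units; that floor lies within the scatter) is accordingly a floor, and the limit of > 100000 nM in this assay, at which 1 of the 2 values shown sits, is where compound 2 sits. Compound 3 `O=C(CCCc1cc2ccccc2[nH]1)OCC1COCCOCCOCCOCCOCCO1` is compound 2 with 2-(1H-indol-2-yl)ethyl in place of but-1-en-1-yl on a saturated chain carbon bound to a carbonyl carbon. The only measured step that bears on this change is the one from compound 1 to compound 2, where 4-phenylbutyl gave way to but-1-en-1-yl and the number rose at least to the floor given above; the present change runs the other way, bringing an aromatic ring back onto the chain, and so points to a lower number, though from a limit its size cannot be read. Compound 3 is expected to come out near where compound 1 stands. The step of an at least 1.6-fold lower number from compound 2 to compound 3 (0.22 log units; that floor lies within the scatter) is what this expectation means. The estimate for compound 3 is 60000 nM, within 20000 nM to 150000 nM.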

Compound 3, concentration for 50% growth inhibition: > 100000 nM
Compound 3: no number, only a limit; the forecaster's own chance of this, stated with the estimate: 35%; at least 1.6-fold (0.22 log units) between middle value and limit.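

In this assay compound 3 reaches only a limit of the assay, > 100000 nM. An aromatic ring on the chain is therefore not enough on its own to give a readable number: 2-(1H-indol-2-yl)ethyl on a saturated chain carbon bound to a carbonyl carbon yields none, 4-phenylbutyl in compound 1 is the only group shown that does, and the step between the two limits cannot be read. With 1H-indol-2-yl in place of phenethyl on a saturated chain carbon, three bonds along the chain from a carbonyl carbon, the result is an at least 1.5-fold higher number from compound 1 to compound 3 (0.19 log units; that floor lies within the scatter), which is a floor only, and the series now gathers at one place: the limit of > 100000 nM in this assay, at which 2 of the 3 values shown sit.

The compounds shown leave open whether the true gap between the phenyl and indole chains lies beyond the scatter, and how far the values under the limit differ. They also leave open whether a longer chain ending in phenyl, or an amine or a carboxylic acid at the end of the acyl chain, would give a number clear of the limit on the shared core.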